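This account rests on a few compounds, and the source may have more. Where it says the series, first, only, none or still open, it means among the compounds named here.

Compound 1 (`CSc1ccc(/C(=N\O)c2cccc3ccccc23)cc1`) is the starting point here. Within the data shown here, in a functional assay on HeLa cells (Homo sapiens) for antiproliferative activity, read by MTT assay, with a stated time of 24 h (a lower number here means that less compound is needed, a higher number that more compound is needed for the effect), compound 1 gives 18000 nM, the higher of the two numbers measured so far. The other measured compound is compound 2 (`CCCCN(C)CCCO/N=C(\c1ccc(SC)cc1)c1cccc2ccccc12`), which gives 8000 nM in the same test. Compound 2 keeps the core of compound 1 but carries 3-(butyl(methyl)amino)propyl in place of hydrogen on an oxygen.

Compound 3 (`CSc1ccc(/C(=N\OCCCCN2CCCCC2)c2cccc3ccccc23)cc1`) changes that same oxygen, this time with a different group (4-(piperidin-1-yl)butyl in place of hydrogen on an oxygen). Like the group in compound 2, the new one holds a nitrogen, although its ring has no measured precedent. Among the measured compounds shown here, only one measured step bears on this change, and it is a modest one: compound 2 shows a 2.3-fold lower number from compound 1 to compound 2 (0.35 log units; beyond the scatter). With a single step as the guide, a similarly modest move toward a lower number is expected in this assay, and the uncertainty stays wide. The expected change is a 2.6-fold lower number from compound 1 to compound 3 (0.41 log units; beyond the scatter) as an estimate. For compound 3 the estimated value is 7000 nM, with 2500 nM to 18000 nM as the expected range.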

Compound 3, half-maximal effective concentration: 18000 nM
For compound 3 the middle estimate is 2.6-fold (0.41 log units) below the measured one; measured number inside the range.
By their numbers in this assay, from the lowest: compound 2; then compounds 1 and 3 (each within the scatter of the next).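

In this assay, attaching a nitrogen-bearing chain to this oxygen does not by itself lower the number: 4-(piperidin-1-yl)butyl gives no change at the digits printed from compound 1 to compound 3 (within the scatter). The earlier pair alone could have suggested that any such chain would help, but the two chains do not behave alike, with a 2.3-fold higher number from compound 2 to compound 3 (0.35 log units; beyond the scatter), a modest step. So the small gain seen with 3-(butyl(methyl)amino)propyl belongs, among these three compounds, to that particular group and not to substitution of the oxygen in general, and no measurement at hand explains the difference.

The step between the two chains changes two features together, the open butyl(methyl)amino end versus the piperidine ring and the propyl versus butyl length, so these compounds cannot show which feature matters. A 3-(piperidin-1-yl)propyl group or a 4-(butyl(methyl)amino)butyl group on the same oxygen would separate the two, each changing only one feature, and a longer chain such as a 5-(piperidin-1-yl)pentyl group would test whether length has any further bearing on the number.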